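Naphthalen-1-yl to naphthalen-2-yl: working notes on the series

The source may hold more compounds than are shown below. What is called first, only, known or untested is meant among the compounds shown, and "the series" means these compounds.

In an ADME assay on L6 cells (Rattus norvegicus) for cytotoxicity, read by resazurin assay (a higher number here means a weaker inhibitor, a lower number a stronger inhibitor), the measured compounds give
Compound 1 (`N=C(N)c1ccc2[nH]c(-c3ccc4nc(-c5ccc(F)cc5)[nH]c4c3)nc2c1`): 2.48 ug/mL
Compound 2 (`CC(C)(C)c1ccc(-c2nc3ccc(-c4nc5cc(C(=N)N)ccc5[nH]4)cc3[nH]2)cc1`): 13 ug/mL
Compound 3 (`N=C(N)c1ccc2[nH]c(-c3ccc4nc(-c5cccc6ccccc56)[nH]c4c3)nc2c1`): 8.72 ug/mL

Compound 3 stands level with compound 2 at the high end of the numbers and well apart from compound 1. The gaps are small on one side (a 1.5-fold lower number from compound 2 to compound 3 (0.17 log units; within the scatter)) and larger on the other (a 3.5-fold higher number from compound 1 to compound 3 (0.55 log units; beyond the scatter)). Compound 4 (`N=C(N)c1ccc2[nH]c(-c3ccc4nc(-c5ccc6ccccc6c5)[nH]c4c3)nc2c1`) carries naphthalen-2-yl in place of naphthalen-1-yl on an aromatic carbon. Among the measured compounds shown here, no measured step compares these two groups directly. For the measured compounds named here, the closest guide is the exchange that stayed inside the scatter (a 1.5-fold lower number from compound 2 to compound 3 (0.17 log units; within the scatter)), whereas the only larger steps start from compound 1 (a 5.2-fold higher number from compound 1 to compound 2 (0.72 log units; beyond the scatter)). No step beyond the scatter is therefore expected in this assay for this change. The estimated step is small (a 1.1-fold lower number from compound 3 to compound 4 (0.04 log units; within the scatter)). Compound 4 is expected at 8 ug/mL, with an estimated range of 3.5 ug/mL to 18 ug/mL.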

Compound 4, half-maximal inhibitory concentration: 34.7 ug/mL
Estimate against measurement, compound 4: 4.3-fold (0.64 log units) below; measured number above the stated range.
By their numbers in this assay, from the lowest: compound 1; then compounds 3 and 2 (each within the scatter of the next); then compound 4.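

In this assay, the two groups have the same atoms joined differently, yet the change alone moves the number beyond the scatter (a 4.0-fold higher number from compound 3 to compound 4 (0.60 log units; beyond the scatter)), so the attachment point of the naphthalene matters at this position. Compound 4 also separates from the other two compounds (a 2.7-fold higher number from compound 2 to compound 4 (0.43 log units; beyond the scatter); a 14-fold higher number from compound 1 to compound 4 (1.15 log units; beyond the scatter)), giving the highest number of the four. Nothing measured here accounts for the gap between the two naphthalene isomers.

Open, on these data alone, is whether an amine or a carboxylic acid on naphthalen-2-yl would keep the number this high.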